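Bromo on the indole ring of the dimethoxyphenyl analogue

The source may report more compounds than this note shows. Statements on the series, on what has been measured and on what is new or still open speak of the compounds shown alone.

Of the compounds shown here, two have been measured in a functional assay on MCF7 cells (Homo sapiens) for cytotoxicity, read by sulforhodamine B assay, with a stated time of 48 h; on this read-out lower numbers stand for higher toxicity in this test and higher numbers for lower toxicity in this test. Compound 1, `COc1cc(/C(Cl)=C/C=C(\C#N)C(=O)c2c[nH]c3ccc(Br)cc23)cc(OC)c1OC`, carries a trimethoxyphenyl group and a bromo on its indole core. In this assay compound 1 returns only a limit, > 100000 nM. Compound 2, `COc1ccc(/C(Cl)=C/C=C(\C#N)C(=O)c2c[nH]c3ccccc23)cc1OC`, differs from compound 1 in having a dimethoxyphenyl group and no bromo. In this assay compound 2 likewise returns only a limit, > 100000 nM. Compound 2 therefore stands at the top end of the numbers shown, with no number resolved for either compound; the two values together form (the limit of > 100000 nM in this assay, at which 2 of the 2 values shown sit).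

Compound 3, `COc1ccc(/C(Cl)=C/C=C(\C#N)C(=O)c2c[nH]c3ccc(Br)cc23)cc1OC`, is the next member to be measured. The change from compound 2 to compound 3 is bromo in place of hydrogen on an aromatic carbon. For the measured compounds named here, no measured step with a number is available to size this change. Given that compound 1, which already carries the same bromo on the same core, sits at the limit > 100000 nM, no step beyond the scatter is expected for compound 3, and a limit read-out is the most likely outcome. The estimate for compound 3 is 150000 nM, within 50000 nM to 500000 nM, corresponding to an expected step that the limit leaves unreadable from compound 2 to compound 3.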

Compound 3, concentration lethal to 50% of the cells: > 100000 nM
Compound 3: no number, only a limit; the forecaster's own chance of this, stated with the estimate: 85%; the middle value does not contradict the limit.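

Compound 3 also returns only a limit, so no step can be read between compound 2 and compound 3 or between compound 1 and compound 3. All three compounds sit at the same limit: the limit of > 100000 nM in this assay, at which 3 of the 3 values shown sit.

The compounds shown leave open whether bromo in place of hydrogen, or hydrogen in place of methoxy, changes the read-out in this assay at all.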